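A Hydroxy Group Added to an Inactive Hydrazone

A few compounds are considered here, and "the series" means these few. Any claim that something is new, unique, unknown or untested is made for them only; others in the source may bear on it.

Compound 3 `Cc1c(C(=O)N/N=C\c2cccc(F)c2)oc2cccc(O)c12` is one of three hydrazones built on a shared core. In a functional assay on PC-3 cells (Homo sapiens) for inhibition (a higher number here means a weaker inhibitor, a lower number a stronger inhibitor), compound 3 reaches only the limit of the assay, >= 40000 nM. Compound 1 `Cc1c(C(=O)N/N=C\c2ccc(O)c(O)c2O)oc2cccc(O)c12` likewise stops at the limit, >= 40000 nM. Compound 2 `Cc1c(C(=O)N/N=C\c2ccc(C(F)(F)F)cc2)oc2cccc(O)c12` also gives no number but the limit, >= 40000 nM. Within the data shown here, compound 3 thus stands together with its two companions at the limit of >= 40000 nM in this assay, at which 3 of the 3 values shown sit, and no step between any pair of them can be measured. Compound 4 `Cc1c(C(=O)N/N=C\c2cccc(F)c2O)oc2cccc(O)c12` differs from compound 3 by hydroxy in place of hydrogen on an aromatic carbon. Compound 1 already carries hydroxy groups and still gives >= 40000 nM. The step from compound 3 to compound 4 is therefore expected to be none beyond the scatter, a step that the limit leaves unreadable from compound 3 to compound 4. Compound 4 is estimated at 50000 nM, within a range from 20000 nM to 150000 nM, most likely again as a limit only.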

Compound 4, half-maximal inhibitory concentration: 12700 nM
Compound 4: the middle estimate sits 3.9-fold (0.60 log units) above what was measured, and the stated range ends above it.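

Hydroxy in place of hydrogen on this aromatic carbon, ortho to a fluoro group, gives an at least 3.1-fold lower number from compound 3 to compound 4 (0.49 log units; beyond the scatter) and so shows that this position responds to the change. Compound 4 is the only compound shown that gives a number rather than a limit. The step can be stated only as a minimum because compound 3 sits at a limit: the limit of >= 40000 nM in this assay, at which 3 of the 4 values shown sit.

From the compounds shown here alone, it remains open whether the fluoro group is needed for this step, and whether a methoxy group, an amine or a carboxylic acid on the same carbon would act as hydroxy does.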